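The source may hold more compounds than are shown below. What is called first, only, known or untested is meant among the compounds shown, and "the series" means these compounds.

In a functional assay on SK-OV-3 cells (Homo sapiens) for inhibition, read by CCK-8 assay, with a stated time of 70 h (a lower number here means a stronger inhibitor, a higher number a weaker inhibitor), compound 1 `c1ccc(COc2ccc(OCCOCCNC3CCCC3)cc2)cc1` gives 24800 nM. Compound 2 `COC(=O)c1ccccc1COc1ccc(OCCOCCNC2CCCC2)cc1` reaches only a limit, > 100000 nM, so its true value is not known. Compound 3 `O=C(O)c1ccc(COc2ccc(OCCOCCNC3CCCC3)cc2)cc1` differs from it as follows: 4-carboxyphenyl in place of 2-(methoxycarbonyl)phenyl on a saturated chain carbon bound to an oxygen on an aromatic ring. That is 4-carboxyphenyl in place of 2-(methoxycarbonyl)phenyl on a saturated chain carbon bound to an oxygen on an aromatic ring. Going by the values given here, one measured step bears on this change: an at least 4.0-fold higher number from compound 1 to compound 2 (0.60 log units; beyond the scatter), where methoxycarbonyl replaced hydrogen on an aromatic carbon. Compound 3 still carries a group on that ring, so it is expected to stay weak, with only a modest move toward a lower number: an estimated at least 1.6-fold lower number from compound 2 to compound 3 (0.22 log units; that floor lies within the scatter). For compound 3 the expected value is 60000 nM, with an estimated range of 20000 nM to 150000 nM.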

Compound 3, half-maximal inhibitory concentration: > 100000 nM
Compound 3: only a limit was reported (the forecaster's own chance of this, stated with the estimate: 45%); middle value at least 1.6-fold (0.22 log units) from the limit.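

Compound 3 shows that the loss seen with methoxycarbonyl is not limited to that group: carboxy in place of hydrogen on an aromatic carbon also gives an at least 4.0-fold higher number from compound 1 to compound 3 (0.60 log units; beyond the scatter). The step from compound 2 to compound 3 cannot be read, because both compounds sit at the same limit: the limit of > 100000 nM in this assay, at which 2 of the 3 values shown sit.

Going by these compounds, how far beyond that limit each compound lies remains open, so methoxycarbonyl and carboxy cannot be ranked. Also open, on these data alone, is whether a smaller group on that ring, such as fluorine or an amine, would keep the activity of compound 1.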